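Propyl-for-methoxy step on the cyclohexyl core

The compounds below may be only part of what the source reports. "The series", "measured", "known", "first", "only" and "open" are said of these compounds alone.

Compound 1 `COc1ccc(-c2c(C)[nH]c(=O)n2C)cc1` gives 147000 nM in a functional assay on brain (Rattus norvegicus, strain Wistar) for inhibition; on this read-out lower numbers stand for stronger inhibition and higher numbers for weaker inhibition. Compound 2 `CCCc1ccc(-c2c(C)[nH]c(=O)n2C)cc1` gives 21500 nM in this assay, and compound 3 `COc1ccc(-c2c(C)[nH]c(=O)n2C2CCCCC2)cc1` gives 20400 nM. The measured steps are a 6.8-fold lower number from compound 1 to compound 2 (0.83 log units; beyond the scatter) and a 7.2-fold lower number from compound 1 to compound 3 (0.86 log units; beyond the scatter); compound 2 and compound 3 lie within the scatter of each other. Compound 4 `CCCc1ccc(-c2c(C)[nH]c(=O)n2C2CCCCC2)cc1` is not yet measured. It differs from compound 3 by propyl in place of methoxy on an aromatic carbon. The same kind of change was already made from compound 1 to compound 2, (propyl in place of methoxy on an aromatic carbon), where the step was a 6.8-fold lower number from compound 1 to compound 2 (0.83 log units; beyond the scatter); the two cores differ by cyclohexyl in place of methyl on an aromatic nitrogen, and the place is described once as para to a large group and once as para to a group of 8 heavy atoms. Because the earlier step was a 6.8-fold lower number from compound 1 to compound 2 (0.83 log units; beyond the scatter), a step of similar direction, a 5.1-fold lower number from compound 3 to compound 4 (0.71 log units; beyond the scatter), is expected from compound 3 to compound 4. Compound 4 is therefore estimated at 4000 nM, between 1500 nM and 12000 nM.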

Compound 4, half-maximal inhibitory concentration: 13900 nM
Estimate against measurement, compound 4: 3.5-fold (0.54 log units) below, and the stated range ends below it.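

Propyl in place of methoxy on an aromatic carbon gives a 1.5-fold lower number from compound 3 to compound 4 (0.17 log units; within the scatter), so in this assay the step does not carry over at its earlier size to the core of compound 3: the same change on two cores in this assay, a 6.8-fold lower number (0.83 log units; beyond the scatter) from compound 1 to compound 2 and a 1.5-fold lower number (0.17 log units; within the scatter) from compound 3 to compound 4, 4.7-fold (0.67 log units) apart, beyond the scatter of two such steps

Read the other way, cyclohexyl in place of methyl on an aromatic nitrogen gives a 1.5-fold lower number from compound 2 to compound 4 (0.19 log units; within the scatter), and this change also depends on the core: the same change on two cores in this assay, a 7.2-fold lower number (0.86 log units; beyond the scatter) from compound 1 to compound 3 and a 1.5-fold lower number (0.19 log units; within the scatter) from compound 2 to compound 4, 4.7-fold (0.67 log units) apart, beyond the scatter of two such steps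

The two changes therefore do not add up across these four compounds, but four compounds cannot show why, nor whether other groups would behave the same way.

Going by these compounds, it remains open whether a longer chain such as butyl, or an amine, in place of propyl would give a step beyond the scatter on the core of compound 3. On these data alone, it is also open whether cyclopentyl or benzyl on the aromatic nitrogen would keep the larger step of the core of compound 1.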